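Benzyl hydroxamate series: a second chlorine on the benzyl ring

A few compounds are considered here, and "the series" means these few. Any claim that something is new, unique, unknown or untested is made for them only; others in the source may bear on it.

Among the compounds with values here, compound 3 `Cc1ccc(-c2nn(-c3ccccc3)cc2C(=O)NOCc2ccccc2Cl)cc1` gives 4680 nM in a functional assay on HeLa cells (Homo sapiens) for antiproliferative activity, read by MTT assay, with a stated time of 48 h, in the presence of a further agent that is not named here (a lower number here means a stronger inhibitor of growth, a higher number a weaker inhibitor of growth), the second highest of the three numbers so far. Compound 1 `Cc1ccc(-c2nn(-c3ccccc3)cc2C(=O)NOCc2ccccc2)cc1` gives 6690 nM in this assay, and this pair lies within the scatter. Compound 2 `Cc1ccc(-c2nn(-c3ccccc3)cc2C(=O)NOCc2ccccc2F)cc1` gives 1180 nM in this assay; the step of a 4.0-fold higher number from compound 2 to compound 3 (0.60 log units; beyond the scatter) is beyond the scatter. Compound 4 `Cc1ccc(-c2nn(-c3ccccc3)cc2C(=O)NOCc2ccc(Cl)cc2Cl)cc1` differs from compound 3 by chloro in place of hydrogen on an aromatic carbon, meta to a chloro group and para to a large group, 2-chlorobenzyl to 2,4-dichlorobenzyl. Within the data shown here, the one measured step of the same kind, a 1.4-fold lower number from compound 1 to compound 3 (0.16 log units; within the scatter), stayed within the scatter, while a 5.7-fold lower number from compound 1 to compound 2 (0.75 log units; beyond the scatter) concerns fluoro and bears less directly. A step no larger than the scatter is therefore expected for compound 4, a 1.3-fold lower number from compound 3 to compound 4 (0.13 log units; within the scatter). Compound 4 is estimated at 3500 nM, in the range 1200 nM to 10000 nM.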

Compound 4, concentration for 50% growth inhibition: 2040 nM
Compound 4: middle estimate off by 1.7-fold (0.23 log units), on the high side, and the stated range covers the measured number.
By their numbers in this assay, from the lowest: compounds 2 and 4 (each within the scatter of the next); then compounds 3 and 1 (each within the scatter of the next).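

Adding chloro para to a large group, 2-chlorobenzyl to 2,4-dichlorobenzyl, moves the number beyond the scatter in this assay (a 2.3-fold lower number from compound 3 to compound 4 (0.36 log units; beyond the scatter)), which the first chloro, in compound 3, did not do against compound 1. The 2,4-dichlorophenyl group also separates from phenyl (a 3.3-fold lower number from compound 1 to compound 4 (0.52 log units; beyond the scatter)), yet stays within the scatter of 2-fluorophenyl (a 1.7-fold higher number from compound 2 to compound 4 (0.24 log units; within the scatter)). No data here account for these steps.

Open, as far as these compounds go, is whether an amine or a methoxy group at this same place would track with chloro. Also open, from the compounds shown here alone, is how a longer chain between the oxygen and the ring would read.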